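This account rests on a few compounds, and the source may have more. Where it says the series, first, only, none or still open, it means among the compounds named here.

Compound 1 `CCn1cc(-c2nc3ccccc3[nH]2)c(=O)c2cc(F)c(N3CCNCC3)nc21` is the parent of one pair. In a functional assay on A2780 cells (Homo sapiens) for cytotoxicity, read by MTT assay, with a stated time of 48 h (a lower number here means a stronger inhibitor, a higher number a weaker inhibitor), compound 1 gives 4800 nM. Compound 3 `CCn1cc(-c2nc3ccc([N+](=O)[O-])cc3[nH]2)c(=O)c2cc(F)c(N3CCNCC3)nc21` differs from it by one change, (nitro in place of hydrogen on an aromatic carbon), and in this assay compound 3 gives 12400 nM; the step of a 2.6-fold higher number from compound 1 to compound 3 (0.41 log units; beyond the scatter) is a modest weakening.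

Compound 2 `CCn1cc(-c2nc3ccccc3o2)c(=O)c2cc(F)c(N3CCNC(C)C3)c(F)c21` has a different core; how the two cores differ is not broken down here. In this assay compound 2 gives 83500 nM, the highest of the three numbers, and its gaps to compound 3 and to compound 1 both lie beyond the scatter.

Compound 4 `CCn1cc(-c2nc3ccc([N+](=O)[O-])cc3o2)c(=O)c2cc(F)c(N3CCNC(C)C3)c(F)c21` is the unmeasured partner of compound 2, carrying the same change, (nitro in place of hydrogen on an aromatic carbon), at the same place. Among the compounds with values here, the expectation is that the step from compound 2 to compound 4 will be a 2.4-fold higher number from compound 2 to compound 4 (0.38 log units; beyond the scatter), resting on the only precedent, the step of a 2.6-fold higher number from compound 1 to compound 3 (0.41 log units; beyond the scatter), with the caution that the cores differ and compound 2 already sits high. Compound 4 is therefore estimated at 200000 nM, with an expected range from 80000 nM to 500000 nM.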

Compound 4, half-maximal inhibitory concentration: 200 nM
Compound 4: the middle estimate sits 1000-fold (3.00 log units) above what was measured; the measured number lies below the stated range.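

In this assay, nitro in place of hydrogen on an aromatic carbon gives a 420-fold lower number from compound 2 to compound 4 (2.62 log units; beyond the scatter) and so makes a large gain in strength on this core, whereas the same change weakened the core of compound 1 modestly. The two steps therefore disagree in direction as well as in size: the same change on two cores in this assay, a 2.6-fold higher number (0.41 log units; beyond the scatter) from compound 1 to compound 3 and a 420-fold lower number (2.62 log units; beyond the scatter) from compound 2 to compound 4, 1100-fold (3.03 log units) apart, beyond the scatter of two such steps. Within the data shown here, this shows that the effect of this change cannot be carried from one core to the other, but with only one pair on each core it does not show which difference between the cores decides the outcome, nor how the change would behave on any third core.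

The compounds shown leave open whether a chlorine or a nitrile in place of the same hydrogen would also give a large gain on the core of compound 2. They also leave open whether the nitro group would do so from another carbon of that six-membered ring.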